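Notes on the fused-core series: compound 2 to compound 4

The source may report more compounds than this note shows. Statements on the series, on what has been measured and on what is new or still open speak of the compounds shown alone.

Measured so far in an assay for inhibition of 15-hydroxyprostaglandin dehydrogenase [NAD(+)] (Homo sapiens), read by fluorescence, with a stated time of 15 min, in the presence of a further agent that is not named here; a higher number here means a weaker inhibitor, a lower number a stronger inhibitor:
compound 1 `CCCC[S+]([O-])c1nc2ccc(-c3cccs3)nc2s1` gives 1230 nM
compound 2 `CCCC[S+]([O-])c1sc2nc(-c3nccs3)cc(-c3nccs3)c2c1N` gives 1.8 nM
compound 3 `CCCC[S+]([O-])c1sc2nc(-c3nccn3C)nc(-c3ccccc3)c2c1N` gives 3.7 nM

Compound 2 holds the lowest number of the three in this assay. Compound 3 stands nearest to it, with a higher number whose gap lies beyond the scatter; compound 1, built on a different core, stands furthest away with a much higher number.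

Compound 4 `CCCC[S+]([O-])c1sc2nc(-c3nccs3)cc(-c3ccc(C(=O)OC)cc3)c2c1N` has not been measured. It differs from compound 2 in one place: 4-(methoxycarbonyl)phenyl in place of 1,3-thiazol-2-yl on an aromatic carbon. Among the measured compounds shown here, no pair of measured compounds differs in this single place, so the size of the step is not known from the series. Compound 3 also carries a six-membered aromatic ring of carbon only on its core, along with other changes, and gives 3.7 nM, which shows that such a ring is tolerated.

From compound 2 to compound 4 the expected step is a 2.2-fold higher number from compound 2 to compound 4 (0.35 log units; beyond the scatter), a modest rise in the number that may not exceed the scatter. Compound 4 is expected to give 4 nM, in a range from 1.2 nM to 15 nM.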

Compound 4, half-maximal inhibitory concentration: 15.1 nM
Beside the measured number, compound 4's estimate is 3.8-fold (0.58 log units) below it; measured number above the stated range.
By their numbers in this assay, from the lowest: compound 2; then compound 3; then compound 4; then compound 1.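

Among the compounds shown here, at the aromatic carbon opposite the ring nitrogen, 4-(methoxycarbonyl)phenyl in place of 1,3-thiazol-2-yl gives in this assay an 8.4-fold higher number from compound 2 to compound 4 (0.92 log units; beyond the scatter), the first single-place reading at this position, and the step lies beyond the scatter. The change costs inhibition without abolishing it: compound 4 still gives 15.1 nM in this assay, so this position accepts a carbon-only six-membered aromatic ring bearing methoxycarbonyl. No evidence is available on what lies behind this step.

The change replaces the ring and introduces methoxycarbonyl together, so the compounds shown do not separate the contribution of each. Unsubstituted phenyl at this position would isolate the ring change, while a carboxylic acid or an amide in place of the methoxycarbonyl would test the substituent.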